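A few compounds are considered here, and "the series" means these few. Any claim that something is new, unique, unknown or untested is made for them only; others in the source may bear on it.

- compound 1 `COc1cc(/C=C/C(=O)/C=C/c2cccc3ccccc23)ccc1OCc1cn(CCOc2cc(=O)oc3ccccc23)nn1`: 4480 nM
- compound 2 `COc1cc(/C=C/C(=O)/C=C/c2cccc3ccccc23)ccc1OCc1cn(CCCOc2cc(=O)oc3ccccc23)nn1`: 8410 nM

In a functional assay on THP-1 cells (Homo sapiens) for cytotoxicity, read by sulforhodamine B assay, with a stated time of 48 h (a higher number here means a weaker inhibitor, a lower number a stronger inhibitor), compound 1 lies within the usual scatter of compound 2, so the two cannot be ranked. Compound 3 `COc1cc(/C=C/C(=O)/C=C/c2cccs2)ccc1OCc1cn(CCOc2cc(=O)oc3ccccc23)nn1` has thiophen-2-yl in place of naphthalen-1-yl on a double-bonded chain carbon bound to a double-bonded chain carbon. Going by the values given here, no measured pair shows what this exchange does, so its direction is uncertain. A modest move towards a higher number, meaning a weaker inhibitor, is expected, shown as the estimated step of a 1.5-fold higher number from compound 1 to compound 3 (0.16 log units; within the scatter). The estimated value for compound 3 is 6500 nM, with an expected range of 2500 nM to 17000 nM.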

Compound 3, half-maximal inhibitory concentration: 7140 nM
Estimate against measurement, compound 3: 1.1-fold (0.04 log units) below; measured number inside the range.
By their numbers in this assay, from the lowest: compounds 1, 3 and 2 (each within the scatter of the next).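

In this assay, replacing naphthalen-1-yl with thiophen-2-yl gives a 1.6-fold higher number from compound 1 to compound 3 (0.20 log units; within the scatter). At this position, on a double-bonded chain carbon bound to a double-bonded chain carbon, a group of 5 heavy atoms including sulfur therefore reads the same as one of 10 carbon atoms, so no difference can be claimed between the two compounds. No available evidence bears on this result.

From the compounds shown here alone, whether an amine or a carboxylic acid at this position would shift the number remains open. So does whether thiophen-2-yl gives the same result alongside the longer chain of compound 2.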